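The source may report more compounds than this note shows. Statements on the series, on what has been measured and on what is new or still open speak of the compounds shown alone.

Compound 3 `COc1ccc2c(=O)c(/C=C/C(=O)NCc3cccc(F)c3)coc2c1` gives 26900 nM in a functional assay on A549 cells (Homo sapiens) for inhibition, read by MTT assay, with a stated time of 48 h (on this read-out higher numbers stand for weaker inhibition and lower numbers for stronger inhibition), the highest of the three numbers; compound 2 `COc1ccc2c(=O)c(/C=C/C(=O)Nc3ccc(C)cc3)coc2c1` gives 17500 nM and compound 1 `COc1ccc2c(=O)c(/C=C/C(=O)Nc3cccc(Cl)c3)coc2c1` gives 470 nM. Compound 4 `COc1ccc2c(=O)c(/C=C/C(=O)Nc3cc(C)ccc3C)coc2c1` differs from compound 3 by 2,5-dimethylphenyl in place of 3-fluorobenzyl on an amide-type nitrogen. For the measured compounds named here, two measured steps bear on this: a 57-fold higher number from compound 1 to compound 3 (1.76 log units; beyond the scatter), which sets a phenyl-type amide against the benzyl, and a 1.5-fold higher number from compound 2 to compound 3 (0.19 log units; within the scatter), which shows a methyl-bearing phenyl sitting within scatter of the benzyl. The ring entering in compound 4 carries two methyl groups and no halogen, so a step nearer to that from compound 2 than from compound 1 is expected, with a 2.7-fold lower number from compound 3 to compound 4 (0.43 log units; beyond the scatter) anticipated. For compound 4 the estimate in this assay is 10000 nM, between 2000 nM and 50000 nM.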

Compound 4, half-maximal inhibitory concentration: 15500 nM
The estimate for compound 4 lay 1.6-fold (0.19 log units) below the measured number; low and high end bracket the measured number.
By their numbers in this assay, from the lowest: compound 1; then compounds 4, 2 and 3 (each within the scatter of the next).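

For the compounds shown here, the 2,5-dimethylphenyl group on the amide-type nitrogen falls in one band with the earlier groups, with no step read against 3-fluorobenzyl (a 1.7-fold lower number from compound 3 to compound 4 (0.24 log units; within the scatter)) or 4-methylphenyl (a 1.1-fold lower number from compound 2 to compound 4 (0.05 log units; within the scatter)). A second methyl group on the phenyl ring therefore does not bring the number towards that of compound 1, and the 3-chlorophenyl group stays apart (a 33-fold higher number from compound 1 to compound 4 (1.52 log units; beyond the scatter)). No available evidence bears on this gap. A 3-methylphenyl group on the amide-type nitrogen would test whether the low number of compound 1 goes with the chlorine or with the ring position it occupies.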